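Triazole-linked flavanone analogues: replacing the allyl group

A few compounds are considered here, and "the series" means these few. Any claim that something is new, unique, unknown or untested is made for them only; others in the source may bear on it.

Measured compounds:
- compound 1, `COc1ccc([C@@H]2CC(=O)c3c(O)cc(OCc4cn(Cc5ccccc5C(F)(F)F)nn4)cc3O2)cc1O`, 12500 nM in a functional assay on RAW264.7 cells (Mus musculus) for inhibition, read by Griess assay, with stated times of 2 h and 24 h; a lower number here means a stronger inhibitor, a higher number a weaker inhibitor
- compound 2, `COc1ccc([C@@H]2CC(=O)c3c(O)cc(OCc4cn(Cc5ccccc5C#N)nn4)cc3O2)cc1O`, 14600 nM in this assay
- compound 3, `C=CCn1cc(COc2cc(O)c3c(c2)O[C@H](c2ccc(OC)c(O)c2)CC3=O)nn1`, 13800 nM in this assay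

In this assay compound 3 gives the second highest of the three numbers, with compound 2 nearest and compound 1 furthest; all three lie within the scatter of one another, so no order among them can be read from the data. Compound 4, `COc1ccc([C@@H]2CC(=O)c3c(O)cc(OCc4cn(Cc5ccc(F)cc5)nn4)cc3O2)cc1O`, is not yet measured. It differs from compound 3 as follows: 4-fluorophenyl in place of vinyl on a saturated chain carbon bound to an aromatic nitrogen. Within the data shown here, two measured steps bear on this change, since both exchange a substituted phenyl on the same saturated chain carbon for vinyl: a 1.1-fold higher number from compound 1 to compound 3 (0.04 log units; within the scatter) and a 1.1-fold lower number from compound 2 to compound 3 (0.02 log units; within the scatter). Neither moved the number beyond the scatter, and the shift from compound 1 to compound 2, a 1.2-fold higher number from compound 1 to compound 2 (0.07 log units; within the scatter), shows that exchanging one substituent on that phenyl for another also changed nothing measurable. For compound 4 no step beyond the scatter is therefore expected, a 1.1-fold lower number from compound 3 to compound 4 (0.03 log units; within the scatter). The value of compound 4 in this assay is estimated at 13000 nM, within 7000 nM to 25000 nM.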

Compound 4, half-maximal inhibitory concentration: 15100 nM
For compound 4 the middle estimate is 1.2-fold (0.07 log units) below the measured one; measured number inside the range.
By their numbers in this assay, from the lowest: compounds 1, 3, 2 and 4 (each within the scatter of the next).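

Across this assay, the exchange of allyl for 4-fluorobenzyl gives a 1.1-fold higher number from compound 3 to compound 4 (0.04 log units; within the scatter) and so adds a third substituted phenyl to the comparison with vinyl at this saturated chain carbon bound to an aromatic nitrogen. Set against the other two substituted phenyl groups, 4-fluorophenyl gives a 1.0-fold higher number from compound 2 to compound 4 (0.01 log units; within the scatter) and a 1.2-fold higher number from compound 1 to compound 4 (0.08 log units; within the scatter), so fluorine on the ring, like nitrile and trifluoromethyl, leaves all four compounds level, with no order among them. No measurement at hand accounts for this flat result.

The four compounds leave open whether any group at this place can move the number beyond the scatter, such as a primary amine or a carboxylic acid on the phenyl ring, or a longer alkyl chain in place of allyl. They also leave open whether a change to the shared core would do so.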